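The compounds below may be only part of what the source reports. "The series", "measured", "known", "first", "only" and "open" are said of these compounds alone.

Of the compounds shown here, two have numbers so far. Compound 1 `CC(C(=O)NCc1ccc(C(F)(F)F)nc1NCc1ccccc1)c1ccc(NS(C)(=O)=O)c(F)c1` carries a benzylamino group on the shared core, and in a functional assay on CHO-K1 cells for antagonist activity at transient receptor potential cation channel subfamily V member 1 (Homo sapiens), read by FLIPR (a higher number here means a weaker inhibitor, a lower number a stronger inhibitor), compound 1 gives 15.8 nM. Compound 2 `CC(C(=O)NCc1ccc(C(F)(F)F)nc1N1CCC(Cc2ccc(F)c(F)c2)CC1)c1ccc(NS(C)(=O)=O)c(F)c1` instead carries a saturated six-membered ring bearing a 3,4-difluorobenzyl group, and in this assay compound 2 gives 0.2 nM. Of the two numbers, compound 2 has the lower one, and the gap to compound 1 is beyond the usual scatter of repeated measurements.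

Compound 3 `CC(C)OC1CCN(c2nc(C(F)(F)F)ccc2CNC(=O)C(C)c2ccc(NS(C)(=O)=O)c(F)c2)CC1` keeps the saturated ring of compound 2 but changes its substituent: isopropoxy in place of 3,4-difluorobenzyl on a saturated ring carbon. Among the measured compounds shown here, no measured pair shows this particular change, so the effect can only be expected, not read off. A move back toward a higher number seems likely, yet not all the way to compound 1, because compound 2 at 0.2 nM shows how strongly this ring arrangement performs. The step from compound 2 to compound 3 is expected to be a 15-fold higher number from compound 2 to compound 3 (1.18 log units; beyond the scatter). Compound 3 is therefore estimated at 3 nM, within a range from 0.5 nM to 20 nM.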

Compound 3, inhibition constant: 3 nM
For compound 3 middle estimate and measured number coincide at the digits printed, within the range that was stated.
By their numbers in this assay, from the lowest: compound 2; then compound 3; then compound 1.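

In this assay, putting isopropoxy in place of 3,4-difluorobenzyl on a saturated ring carbon gives a 15-fold higher number from compound 2 to compound 3 (1.18 log units; beyond the scatter), so the group at this ring carbon has a large influence on the number. The other step, 4-isopropoxypiperidin-1-yl in place of benzylamino on an aromatic carbon, gives a 5.3-fold lower number from compound 1 to compound 3 (0.72 log units; beyond the scatter), which shows that a number lower than that of compound 1 does not require the 3,4-difluorobenzyl group. Nothing measured here explains why either step has its size.

Going by these compounds, what remains open is whether the aromatic ring of the benzyl group or its two fluorines account for the lower number of compound 2. An unsubstituted benzyl group, a methoxy group or an amine on the same ring carbon would help to separate these contributions.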